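Fluoro for methoxy on the sulfanyl aryl ring

A few compounds are considered here, and "the series" means these few. Any claim that something is new, unique, unknown or untested is made for them only; others in the source may bear on it.

Notes on a small set sharing one core that carries two amino groups and a phenyl. Compound 1 `CCOC(=O)[C@H](CCC(=O)O)NC(=O)c1ccc(Oc2nc3cc(N)cc(N)c3nc2-c2ccccc2)cc1` bears an ether-linked benzamide arm; in a functional assay on Hs-578T cells (Homo sapiens) for inhibition, read by sulforhodamine B assay, with a stated time of 48 h (a lower number here means a stronger inhibitor of growth, a higher number a weaker inhibitor of growth), compound 1 gives 43700 nM. Compound 2 `COc1ccc(Sc2nc3cc(N)cc(N)c3nc2-c2ccccc2)cc1` instead carries a (4-methoxyphenyl)sulfanyl group. For compound 2 in this assay only a limit is known, < 100000 nM. Within the data shown here, that is where compound 2 stands: its figure is a limit and not a number, and it is the one of the two values shown that sits at that limit (the limit of < 100000 nM in this assay, at which 1 of the 2 values shown sits). Among the measured compounds shown here, no step between measured compounds that differ in one place is available, so nothing measured tells how a change on this aryl ring moves the read-out.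

Compound 3 `Nc1cc(N)c2nc(-c3ccccc3)c(Sc3ccc(F)cc3)nc2c1` is not yet measured. It differs from compound 2 by fluoro in place of methoxy on an aromatic carbon. Expectation for this assay: no step beyond the scatter, the change from compound 2 to compound 3 being estimated at a step that the limit leaves unreadable from compound 2 to compound 3. Compound 3 is expected to give 50000 nM, with a range from 15000 nM to 100000 nM, and a fair chance that only a limit is reported.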

Compound 3, concentration for 50% growth inhibition: 26900 nM
Compound 3: middle estimate off by 1.9-fold (0.27 log units), on the high side, within the range that was stated.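

No step can be read from compound 2 to compound 3, because the figure for compound 2 in this assay is a limit and not a number: the limit of < 100000 nM in this assay, at which 1 of the 3 values shown sits.

The compounds shown leave open how fluoro and methoxy on this aryl ring compare in this assay, and whether a change at this place on the shared core moves growth inhibition at all.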